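Changing the Amide Side Chain of Compound 1

The source may hold more compounds than are shown below. What is called first, only, known or untested is meant among the compounds shown, and "the series" means these compounds.

Measured compounds:
compound 1, `CCn1c(C(=O)NCCCN(C)C)ccc1C(CC)(CC)c1ccc(OCCC(O)(CC)CC)c(C)c1`: 110 nM
compound 2, `CCn1c(C(=O)NCC#N)ccc1C(CC)(CC)c1ccc(OCCC(O)(CC)CC)c(C)c1`: > 50000 nM
compound 3, `CCn1c(C(=O)NCCN)ccc1C(CC)(CC)c1ccc(OCCC(O)(CC)CC)c(C)c1`: 1590 nM

In a functional assay on HepG2 cells (Homo sapiens) for antiproliferative activity, read by MTT assay, with a stated time of 48 h (on this read-out lower numbers stand for stronger inhibition and higher numbers for weaker inhibition), compound 1 gives 110 nM, the lowest of the two numbers reported. Compound 3 gives 1590 nM. For compound 2 the result is a limit of the assay, > 50000 nM, not a number. The steps are large: an at least 450-fold higher number from compound 1 to compound 2 (2.65 log units; beyond the scatter), a 14-fold higher number from compound 1 to compound 3 (1.16 log units; beyond the scatter) and an at least 31-fold lower number from compound 2 to compound 3 (1.49 log units; beyond the scatter). Every alteration of the (dimethylamino)propyl side chain of compound 1 thus raised the number markedly.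

Compound 4, `C=CCN(C)C(=O)c1ccc(C(CC)(CC)c2ccc(OCCC(O)(CC)CC)c(C)c2)n1CC`, differs from compound 1 by allyl(methyl)amino in place of (3-(dimethylamino)propyl)amino on a carbonyl carbon. The new group keeps neither the chain length nor the dimethylamino group of compound 1, so the two measured steps, both large and both upward, bear on it, and a large upward step is expected. Compound 4 is therefore estimated at 20000 nM, with a range from 3000 nM to 150000 nM. For compound 4 the expected step is a 180-fold higher number from compound 1 to compound 4 (2.26 log units; beyond the scatter).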

Compound 4, half-maximal inhibitory concentration: > 50000 nM
Compound 4 ended at the assay's limit; the forecaster's own chance of this, stated with the estimate: 40%; middle value at least 2.5-fold (0.39 log units) away from the limit.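

In this assay, allyl(methyl)amino in place of (3-(dimethylamino)propyl)amino on the carbonyl carbon gives an at least 450-fold higher number from compound 1 to compound 4 (2.65 log units; beyond the scatter), and this is the only change shown that removes the amide hydrogen along with the terminal dimethylamino group. Compared with the (2-aminoethyl)amino side chain, the result is an at least 31-fold higher number from compound 3 to compound 4 (1.49 log units; beyond the scatter), so among these four compounds, the two side chains ending in an amine, in compound 1 and compound 3, give readable numbers, while compound 2 and compound 4, whose side chains have no such terminal amine, do not. The result for compound 4 is a limit of the assay, as is the result for compound 2, and the step between these two compounds cannot be read: the limit of > 50000 nM in this assay, at which 2 of the 4 values shown sit.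

Compound 4 changes the chain, the terminal amine and the amide hydrogen at once, so the compounds shown cannot say which of these changes accounts for the loss. Also open, on these data alone, is whether a methyl on the amide nitrogen with the (dimethylamino)propyl chain kept, or a longer chain ending in a dimethylamino group, would hold or lower the number of compound 1.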